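A Nitro Group on the Lowest of Three

This account rests on a few compounds, and the source may have more. Where it says the series, first, only, none or still open, it means among the compounds named here.

In a functional assay on MCF7 cells (Homo sapiens) for antiproliferative activity, read by MTT assay, with stated times of 24 h and 72 h (a higher number here means a weaker inhibitor, a lower number a stronger inhibitor), compound 1 (`COc1ccc([C@@H]2[C@H](Oc3ccccc3)C(=O)N2c2cc(OC)c(OC)c(OC)c2)cc1`) gives 35000 nM, compound 2 (`COc1ccc([C@@H]2[C@@H](Oc3ccccc3)C(=O)N2c2cc(OC)c(OC)c(OC)c2)cc1`) gives 6900 nM, and compound 3 (`COc1cccc([C@@H]2[C@H](Oc3ccccc3)C(=O)N2c2cc(OC)c(OC)c(OC)c2)c1`) gives 171000 nM. Compound 2 is the lowest of the three, with a 5.1-fold lower number from compound 1 to compound 2 (0.71 log units; beyond the scatter), a step that rests on (the fact that compounds 1 and 2 differ only in the configuration as drawn). Compound 4 (`COc1ccc([C@@H]2[C@@H](Oc3ccccc3)C(=O)N2c2cc(OC)c(OC)c(OC)c2)cc1[N+](=O)[O-]`) has one change from compound 2: nitro in place of hydrogen on an aromatic carbon, ortho to a methoxy group. Going by the values given here, no measured step adds a group there. The closest guide is a change on the same ring, moving the methoxy group, with a 4.9-fold higher number from compound 1 to compound 3 (0.69 log units; beyond the scatter). It shows that this ring can move the number by a modest amount in compound 3, but it sets no direction for nitro. The expected step is a 1.4-fold lower number from compound 2 to compound 4 (0.14 log units; within the scatter), estimated as no larger than that guide, with its direction open. The estimated value for compound 4 is 5000 nM, with a range from 1000 nM to 30000 nM.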

Compound 4, half-maximal inhibitory concentration: 4100 nM
For compound 4 the middle estimate is 1.2-fold (0.09 log units) above the measured one, within the range that was stated.
By their numbers in this assay, from the lowest: compounds 4 and 2 (each within the scatter of the next); then compound 1; then compound 3.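

In this assay nitro in place of hydrogen on this aromatic carbon, ortho to a methoxy group, gives a 1.7-fold lower number from compound 2 to compound 4 (0.23 log units; within the scatter) and so leaves compound 4 level with compound 2. Going by these compounds alone, this position therefore takes the 4-methoxy-3-nitrophenyl group with no change that can be told from the scatter, which the earlier compounds could not show. Nothing known here explains this result. As far as these compounds go, whether an amine or a hydroxyl group at this position would also leave the number level stays open. So does whether nitro would give the same result in the configuration of compound 1.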